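The compounds below may be only part of what the source reports. "The series", "measured", "known", "first", "only" and "open" are said of these compounds alone.

Values in a functional assay on the whole organism for inhibition, with Rattus norvegicus as the target, read by ELISA and paw edema, using microsomes, in plasma, with stated times of 1 h and 2 h, at a dose of 10 umol/kg by the subcutaneous route (on this read-out lower numbers stand for less inhibition and higher numbers for more inhibition at the one dose given (going by the name of the read-out)), for the measured compounds:

compound 1, `N#Cc1cnn(-c2ccc(S(N)(=O)=O)cc2)c1NC(=O)CCl`: 80.7%
compound 2, `CC(=O)Nc1c(C#N)cnn1-c1ccc(S(=O)(=O)NC(C)=O)cc1`: 80%
compound 3, `N#Cc1cnn(-c2ccc(S(N)(=O)=O)cc2)c1/N=C/c1ccc(F)cc1`: 74.7%

Compound 3 gives the smallest of the three numbers, but its gap to compound 2 and its gap to compound 1 both lie within the usual scatter of this read-out, so no order among the three can be claimed; all three sit in the same band of inhibition.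

Compound 4, `COc1ccc(/C=N/c2c(C#N)cnn2-c2ccc(S(N)(=O)=O)cc2)cc1`, is not yet measured. It differs from compound 3 in one place only: methoxy in place of fluoro on an aromatic carbon. Going by the values given here, no pair of measured compounds carries the same change, so nothing measured tells the size or direction of its effect. Given that compound 3 gives 74.7% and that the other two compounds, with different groups in the same region, remain within the scatter of it, the expectation is that the step of a number 1.3 percentage points higher from compound 3 to compound 4 (within the scatter) stays within the scatter, with no direction favoured. Compound 4 is therefore estimated at 76%, with a range from 62% to 88%.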

Compound 4, a percentage reported as inhibition, in the whole organism at one dose (the size of the read-out at that dose, not a potency): 80.3%
Compound 4: middle estimate off by 4.3 percentage points, on the low side; the range from low to high includes it.
By their numbers in this assay, from the lowest: compounds 3, 2, 4 and 1 (each within the scatter of the next).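

In this assay, going by these compounds alone, methoxy in place of fluoro on an aromatic carbon, para to a large group, gives a number 5.6 percentage points higher from compound 3 to compound 4 (within the scatter) and provides the first reading of a change at this position. The 4-fluorophenyl and 4-methoxyphenyl compounds therefore cannot be told apart on this read-out, although methoxy brings a hydrogen-bond acceptor that fluoro does not. No measurement shown bears on why the two compounds read alike. On these data alone, whether an amine or a carboxylic acid on the same aromatic carbon would stay within the scatter of compound 3 remains open. As far as these compounds go, with a single pair carrying this change and a read-out taken at one dose, it also remains open whether the same swap would read alike on another core or at another dose.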